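The source may hold more compounds than are shown below. What is called first, only, known or untested is meant among the compounds shown, and "the series" means these compounds.

Measured compounds:
compound 1 `CCCCCCCOc1c(-c2cc(OC)c(OC)c(OC)c2)oc2ccccc2c1=O` — > 50000 nM
compound 2 `CCN(CC)CCCCCOc1c(-c2cc(OC)c(OC)c(OC)c2)oc2ccccc2c1=O` — 6600 nM
compound 3 `CCCN(CCC)CCCOc1c(-c2cc(OC)c(OC)c(OC)c2)oc2ccccc2c1=O` — 16800 nM

In a functional assay on PC-3 cells (Homo sapiens) for antiproliferative activity, read by WST assay, with a stated time of 3 days (a higher number here means a weaker inhibitor, a lower number a stronger inhibitor), compound 1 reaches only a limit of the assay, > 50000 nM; no number is known for it. The two amine-bearing compounds give numbers: compound 2 gives 6600 nM and compound 3 gives 16800 nM in this assay.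

The next compound is compound 4 `CCCCN(CCCC)CCCOc1c(-c2cc(OC)c(OC)c(OC)c2)oc2ccccc2c1=O`. It differs from compound 1 by dibutylamino in place of butyl on a saturated chain carbon, three bonds along the chain from an oxygen on an aromatic ring.

Among the compounds with values here, two measured steps bear on this change. The step of an at least 7.5-fold lower number from compound 1 to compound 2 (0.87 log units; beyond the scatter) and the step of an at least 2.9-fold lower number from compound 1 to compound 3 (0.47 log units; beyond the scatter) both run from the same starting point, and both introduce a tertiary amine onto the chain; each leaves the limit behind, so their true size is known only as a lower bound (the limit of > 50000 nM in this assay, at which 1 of the 3 values shown sits). The closer model is compound 3, which carries its amine at the same place along the chain; compound 4 only lengthens each arm of that amine. Between the two amine compounds, a 2.5-fold higher number from compound 2 to compound 3 (0.41 log units; beyond the scatter) shows that the kind and placement of the amine shifts the number modestly.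

For compound 4 a drop from the limit of compound 1 of at least the size seen for compound 3 is therefore expected, an at least 3.8-fold lower number from compound 1 to compound 4 (0.58 log units; beyond the scatter), landing near compound 3. Compound 4 is estimated at 13000 nM, within 4000 nM to 40000 nM.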

Compound 4, half-maximal inhibitory concentration: 7100 nM
Compound 4: the middle estimate sits 1.8-fold (0.26 log units) above what was measured, and the stated range covers the measured number.
By their numbers in this assay, from the lowest: compounds 2 and 4 (each within the scatter of the next); then compound 3. At a limit, above all of these: compound 1.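

In this assay, within the data shown here, the arms of the amine turn out to matter even when its place on the chain stays the same: dibutylamino in place of dipropylamino gives a 2.4-fold lower number from compound 3 to compound 4 (0.37 log units; beyond the scatter) and so moves the number beyond the scatter, which no earlier pair could show. The 2-(diethylamino)ethyl and dibutylamino changes at this place cannot be told apart in this assay, with a 1.1-fold higher number from compound 2 to compound 4 (0.03 log units; within the scatter) as the step between them. Against the amine-free chain of compound 1, the step of an at least 7.0-fold lower number from compound 1 to compound 4 (0.84 log units; beyond the scatter) gives only a lower bound on the gain from dibutylamino: the limit of > 50000 nM in this assay, at which 1 of the 4 values shown sits.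

The compounds shown leave open whether arms longer than butyl, such as those of a dipentylamino group, or a ring amine such as piperidine or morpholine would carry the change further at this place. They also leave open what a diethylamino group would give on the chain of compound 3, so the effect of the amine's arms cannot yet be separated from that of the chain carrying it.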